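Tetrabromobenzotriazole side chains and MCF7 antiproliferative activity

The compounds below may be only part of what the source reports. "The series", "measured", "known", "first", "only" and "open" are said of these compounds alone.

Measured compounds:
compound 1 `OC(CCn1nc2c(Br)c(Br)c(Br)c(Br)c2n1)c1cccc(Br)c1`: 11%
compound 2 `C[C@H](O)CCn1nc2c(Br)c(Br)c(Br)c(Br)c2n1`: 87%

In a functional assay on MCF7 cells (Homo sapiens) for antiproliferative activity, read by MTT assay, with a stated time of 48 h, tested at 50 uM (on this read-out higher numbers stand for a weaker effect at the one concentration tested and lower numbers for a stronger effect), compound 1 gives 11%. In this assay compound 2 gives 87%, the highest of the two numbers, and its distance from compound 1 lies beyond the scatter. Among the compounds with values here, no step between the two measured compounds is tracked here, so only the two values themselves are known.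

Compound 3 `OCC(O)Cn1nc2c(Br)c(Br)c(Br)c(Br)c2n1` has not yet been measured. It differs from compound 2 in one place: 1,2-dihydroxyethyl in place of 2-hydroxypropyl on a saturated chain carbon bound to an aromatic nitrogen. Within the data shown here, both compounds keep the shared core and a short saturated chain bound to an aromatic nitrogen, and no measured pair shows what such a change does. Compound 3 is therefore expected to stay close to compound 2, with a step of a number 7 percentage points lower from compound 2 to compound 3 (within the scatter) in this assay that need not exceed the scatter. The expected value for compound 3 is 80%, within 55% to 100%.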

Compound 3, a percentage reported as activity, at one concentration (the size of the read-out at that concentration, not a potency): 109%
Estimate against measurement, compound 3: 29 percentage points below; measured number outside the range, above it.
By their numbers in this assay, from the lowest: compound 1; then compound 2; then compound 3.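

At this position, on a saturated chain carbon bound to an aromatic nitrogen, 1,2-dihydroxyethyl in place of 2-hydroxypropyl gives a step of a number 22 percentage points higher from compound 2 to compound 3 (beyond the scatter) in this assay, which on this read-out means a weaker effect at the one concentration tested. Within the data shown here, this is the first single change tracked, and it shows that even a swap between two short side chains of equal heavy-atom count can register beyond the scatter. Nothing available explains the direction of this step.

The compounds shown do not separate the second hydroxy group from the loss of the defined stereocentre that 2-hydroxypropyl carries. Going by these compounds, whether an amine, a carboxylic acid or a longer chain at this position would shift the read-out in the same direction remains open.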